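Methoxy on the aromatic ring of a fused indoline-type diterpenoid

A few compounds are considered here, and "the series" means these few. Any claim that something is new, unique, unknown or untested is made for them only; others in the source may bear on it.

Three compounds built on a shared terpenoid core were tested in a functional assay on SW1573 cells (Homo sapiens) for inhibition, read by sulforhodamine B assay, with a stated time of 48 h; on this read-out higher numbers stand for weaker inhibition of growth and lower numbers for stronger inhibition of growth. Compound 1 `COC(=O)[C@@]1(C)CCC=C2[C@@H]1CC[C@@H](C)[C@]2(C)Cc1c[nH]c2ccc(C)cc12` gives 15000 nM in this assay. Compound 2 `COC(=O)[C@@]1(C)CCC=C2[C@@H]1CC[C@@H](C)[C@]2(C)Cc1c(C)[nH]c2ccccc12` gives 14000 nM. Compound 3 `COC(=O)[C@@]1(C)CC[C@@H]2C3=C1CC[C@@H](C)[C@]3(C)C[C@@H]1c3ccccc3N[C@H]21`, in which the indole of the first two is replaced by a ring-fused dihydro arrangement, gives 30000 nM. Going by the values given here, of the three numbers, the one for compound 3 is the highest; it lies within the usual scatter of compound 1 but beyond it relative to compound 2, so compound 3 can be called the weakest growth inhibitor only against compound 2.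

The next compound, compound 4 `COC(=O)[C@@]1(C)CC[C@@H]2C3=C1CC[C@@H](C)[C@]3(C)C[C@@H]1c3cc(OC)ccc3N[C@H]21`, differs from compound 3 by a single change: methoxy in place of hydrogen on an aromatic carbon. Among the compounds with values here, no measured pair in this set shows the effect of this kind of substitution, so there is no step here to borrow from. Given that the three measured compounds all sit in a narrow band, the change from compound 3 to compound 4 is expected to be small, with no clear direction and probably none beyond the scatter, that is a 1.2-fold lower number from compound 3 to compound 4 (0.08 log units; within the scatter). Compound 4 is therefore estimated at 25000 nM in this assay, within a range from 8000 nM to 70000 nM.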

Compound 4, concentration for 50% growth inhibition: 25000 nM
Compound 4: middle estimate and measured number agree at the digits printed; measured number inside the range.
By their numbers in this assay, from the lowest: compounds 2, 1, 4 and 3 (each within the scatter of the next, the first and the last beyond it).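

Going by these compounds alone, this pair gives the first reading of a substitution on the aromatic ring of the fused compounds, since the earlier compounds offered no step of any kind. In this assay, methoxy in place of hydrogen on an aromatic carbon, meta to a fused ring and para to a fused ring, gives a 1.2-fold lower number from compound 3 to compound 4 (0.08 log units; within the scatter), a step within the usual scatter, so this position accepts the methoxy group with no change in growth inhibition that can be told from repeat measurement, and the substitution brings no demonstrable gain. No supporting measurement bears on why the step is this small.

Going by these compounds, what stays open is whether this position would respond in the same way to a different group, such as an amine, a carboxylic acid or a longer chain like butoxy, or whether only methoxy leaves the number within the scatter. On these data alone, it is also open whether methoxy on another carbon of the same aromatic ring would read alike, and whether any change on this ring can take the fused compounds clearly beyond the scatter in either direction.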